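The source may report more compounds than this note shows. Statements on the series, on what has been measured and on what is new or still open speak of the compounds shown alone.

Measured so far:
compound 1 `CSc1ccc(C)cc1NCC1=NCCN1` — 0.912 nM
compound 2 `CS(=O)(=O)c1ccc(Cl)cc1NCC1=NCCN1` — < 100000 nM
compound 3 `CS(=O)(=O)c1ccc(F)cc1NCC1=NCCN1` — < 100000 nM

In a functional assay for agonist activity at Alpha-1D adrenergic receptor (Homo sapiens) (on this read-out higher numbers stand for an effect only at larger amounts of compound and lower numbers for an effect already at smaller amounts), compound 1 gives 0.912 nM. For compound 2 only a limit of the assay is given, < 100000 nM. Compound 3 likewise sits at a limit, < 100000 nM. The step that the two limits leave unreadable from compound 2 to compound 3 therefore cannot be read, because the limit of < 100000 nM in this assay, at which 2 of the 3 values shown sit, caps both ends.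

Compound 4 `CSc1ccc(Cl)cc1NCC1=NCCN1` is not yet measured. It differs from compound 2 by methylsulfanyl in place of methylsulfonyl on an aromatic carbon. Within the data shown here, no measured step covers this change; the two limits give no size. Compound 1 carries the same methylsulfanyl group and gives 0.912 nM, which anchors the expectation for compound 4 in this assay with a wide range, a step that the limit leaves unreadable from compound 2 to compound 4 expected. Compound 4 is estimated at 3 nM, expected between 0.3 nM and 30 nM.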

Compound 4, half-maximal effective concentration: 2.69 nM
For compound 4 the middle estimate is 1.1-fold (0.05 log units) above the measured one; measured number inside the range.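

In this assay compound 4, with methylsulfanyl on this aromatic carbon, gives a readable value of 2.69 nM. Compound 2, with methylsulfonyl there, is only a limit, < 100000 nM, and no step that touches this limit can be read: the limit of < 100000 nM in this assay, at which 2 of the 4 values shown sit.

With methylsulfanyl kept, chloro in place of methyl gives a 2.9-fold higher number from compound 1 to compound 4 (0.47 log units; beyond the scatter), so the low value does not rest on the methyl group alone. Open, as far as these compounds go, is what fluoro in place of chloro gives with methylsulfanyl kept. Also open, from the compounds shown here alone, is what methoxy or a longer chain such as ethylsulfanyl gives on the same aromatic carbon.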